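A Trifluoromethyl Group Added to Compound 3

This account rests on a few compounds, and the source may have more. Where it says the series, first, only, none or still open, it means among the compounds named here.

- Compound 1 `O=c1nc2ccccn2cc1Cc1ccc(F)cc1C(F)(F)F`: 8690 nM
- Compound 2 `Cc1ccc(Cc2cn3cc(Cl)ccc3nc2=O)cc1`: 860 nM
- Compound 3 `O=c1nc2ccc(Cl)cn2cc1Cc1ccc(F)cc1`: 9860 nM

All three compounds were tested in a functional assay on SK-N-SH cells (Homo sapiens) for cytotoxicity, read by MTT assay, with a stated time of 24 h; a higher number here means a weaker inhibitor, a lower number a stronger inhibitor. Among the compounds with values here, compound 3 gives 9860 nM, and this value lies within the usual scatter of the one for compound 1. Compound 2 gives 860 nM, the lowest number of the three by a wide margin.

Compound 4 `O=c1nc2ccc(Cl)cn2cc1Cc1ccc(F)cc1C(F)(F)F` has not yet been measured. It departs from compound 3 by a single change, trifluoromethyl in place of hydrogen on an aromatic carbon, ortho to a large group and meta to a fluoro group.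

Within the data shown here, only one measured step connects compounds that differ in one place: an 11-fold higher number from compound 2 to compound 3 (1.06 log units; beyond the scatter), a large step with fluoro in place of methyl on an aromatic carbon. That is a different exchange of groups, and it does not measure the effect of adding trifluoromethyl. Compound 4 shares its trifluoromethyl group with compound 1, which lacks the chloro group and gives 8690 nM, within the scatter of the value of compound 3. On this evidence, no step beyond the scatter is expected in this assay, and neither direction is favoured.

The estimated change is a 1.2-fold lower number from compound 3 to compound 4 (0.09 log units; within the scatter). Compound 4 is expected at 8000 nM, with an estimated range of 3000 nM to 20000 nM.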

Compound 4, half-maximal inhibitory concentration: 106000 nM
Compound 4: middle estimate off by 13-fold (1.12 log units), on the low side, outside the stated range (above it).
By their numbers in this assay, from the lowest: compound 2; then compounds 1 and 3 (each within the scatter of the next); then compound 4.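

In this assay the trifluoromethyl group on this aromatic carbon, ortho to a large group and meta to a fluoro group, is far from neutral: its addition gives an 11-fold higher number from compound 3 to compound 4 (1.03 log units; beyond the scatter) as a large step. The chloro group matters too when the trifluoromethyl group is present, since chloro in place of hydrogen gives a 12-fold higher number from compound 1 to compound 4 (1.09 log units; beyond the scatter) as a second large step in the same direction. Within the data shown here, each of the two groups thus raises the number when added to a compound that carries the other, something the earlier compounds could not show, as they offered no measured step for either change. No measurement shown here bears on why the number rises.

The compounds shown leave open whether the rise belongs to trifluoromethyl in particular or would also follow from a smaller or different group at this position, such as methyl, methoxy or an amine. They also leave open whether the same addition would give a step of this size on compound 2, which carries methyl in place of the fluoro group.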